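Swapping a basic amine side chain for a triazole diol

The source may hold more compounds than are shown below. What is called first, only, known or untested is meant among the compounds shown, and "the series" means these compounds.

Measured compounds:
compound 1 `CN1CCN(CCCCCCn2c3c(c4ccccc42)C(=O)c2c[n+]([O-])c4ccccc4c2C3=O)CC1` gives 630 nM
compound 2 `O=C1c2c[n+]([O-])c3ccccc3c2C(=O)c2c1c1ccccc1n2Cc1cn([C@H]2C[C@H](O)[C@@H](CO)O2)nn1` gives 390 nM
compound 3 `O=C1c2c[n+]([O-])c3ccccc3c2C(=O)c2c1c1ccccc1n2CCN1CCCC1` gives 430 nM

The three compounds share one core and differ only in the group carried on the aromatic nitrogen. In a functional assay on A-375 cells (Homo sapiens) for cytotoxicity, read by MTT assay, with a stated time of 72 h (a higher number here means a weaker inhibitor, a lower number a stronger inhibitor), compound 3 gives 430 nM, and the three numbers lie close together: the gaps to compound 2 and to compound 1 are both within the usual scatter, so none of the three can be called stronger or weaker than another.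

Compound 4 `O=C1c2c[n+]([O-])c3ccccc3c2C(=O)c2c1c1ccccc1n2Cc1cn(C[C@H](O)CO)nn1` arises from compound 3 by the change (1-(2,3-dihydroxypropyl)-1H-1,2,3-triazol-4-yl in place of (pyrrolidin-1-yl)methyl on a saturated chain carbon bound to an aromatic nitrogen). For the measured compounds named here, only one measured step touches this position, a 1.5-fold lower number from compound 1 to compound 3 (0.17 log units; within the scatter), and it was within the scatter. Compound 2, which also carries a triazole with a hydroxylated substituent on this side chain, gives 390 nM, again no further from compound 3 than the scatter allows. Every variation at this position that has been measured so far has left the number essentially unchanged, so no step beyond the scatter is expected in this assay. For compound 4 the expected step is a 1.0-fold lower number from compound 3 to compound 4 (0.01 log units; within the scatter). The estimate for compound 4 is 420 nM, with a range from 200 nM to 900 nM.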

Compound 4, half-maximal inhibitory concentration: 350 nM
Estimate against measurement, compound 4: 1.2-fold (0.08 log units) above; the range from low to high includes it.
By their numbers in this assay, from the lowest: compounds 4, 2, 3 and 1 (each within the scatter of the next).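

In this assay, 1-(2,3-dihydroxypropyl)-1H-1,2,3-triazol-4-yl in place of (pyrrolidin-1-yl)methyl gives a 1.2-fold lower number from compound 3 to compound 4 (0.09 log units; within the scatter): a ring amine gives way to a larger triazole group bearing a diol, with hydrogen-bond donors where the leaving group has none, and the number stays within the scatter. The open-chain diol and the ring it replaces on the triazole cannot be told apart either, since 2,3-dihydroxypropyl in place of 4-hydroxy-5-(hydroxymethyl)oxolan-2-yl on an aromatic nitrogen gives a 1.1-fold lower number from compound 2 to compound 4 (0.05 log units; within the scatter). Even the change from the long piperazine-bearing chain to the triazole diol, a 1.8-fold lower number from compound 1 to compound 4 (0.26 log units; within the scatter), remains within the scatter, so across these four compounds this position accepts very different groups with no readable change in the assay.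

Still open, going by these compounds, is whether any group here can move the number beyond the scatter, for example a carboxylic acid in place of the 2,3-dihydroxypropyl group or a simple methyl on the aromatic nitrogen. No measurement at hand explains why these groups give such similar numbers.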